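Replacing 3-(4-methylpiperazin-1-yl)propyl with 4-(dimethylamino)butyl

This account rests on a few compounds, and the source may have more. Where it says the series, first, only, none or still open, it means among the compounds named here.

Within the data shown here, in a functional assay on A549 cells (Homo sapiens) for cytotoxicity, read by MTT assay, with a stated time of 72 h (a lower number here means a stronger inhibitor, a higher number a weaker inhibitor), compound 2 (`CN1CCN(CCCn2c3c(c4ccccc42)C(=O)c2c[n+]([O-])c4ccccc4c2C3=O)CC1`) gives 140 nM and holds the lowest of the two numbers so far. In this assay compound 1 (`O=C1c2c[n+]([O-])c3ccccc3c2C(=O)c2c1c1ccccc1n2CCN1CCCC1`) gives 410 nM as the other number. Compound 3 (`CN(C)CCCCn1c2c(c3ccccc31)C(=O)c1c[n+]([O-])c3ccccc3c1C2=O`) has not yet been measured. On the same shared core, it carries 4-(dimethylamino)butyl where compound 2 carries 3-(4-methylpiperazin-1-yl)propyl ((dimethylamino)methyl in place of 4-methylpiperazin-1-yl on a saturated chain carbon, three bonds along the chain from an aromatic nitrogen). Among the measured compounds shown here, only one measured step bears on this change, and it also alters the chain on the aromatic nitrogen (a 2.9-fold lower number from compound 1 to compound 2 (0.47 log units; beyond the scatter)). That step is modest, and a single step is thin evidence. Nothing measured yet shows what happens when the group that enters has no ring. Compound 2 sits at the low end of just two numbers, so a move back up seems more likely than a further drop. A step of similar or smaller size is expected, with a higher number the likelier direction (a 1.6-fold higher number from compound 2 to compound 3 (0.22 log units; within the scatter)). For compound 3 the estimated value is 230 nM (expected range 80 nM to 650 nM).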

Compound 3, half-maximal inhibitory concentration: 310 nM
Beside the measured number, compound 3's estimate is 1.3-fold (0.13 log units) below it; low and high end bracket the measured number.
By their numbers in this assay, from the lowest: compound 2; then compounds 3 and 1 (each within the scatter of the next).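

Set against 3-(4-methylpiperazin-1-yl)propyl, the ring-free 4-(dimethylamino)butyl group on the aromatic nitrogen gives up part of the activity in this assay, with a 2.2-fold higher number from compound 2 to compound 3 (0.35 log units; beyond the scatter). Having a ring at the end of the chain is not enough on its own to give a low number: compound 1 also ends in a ring, pyrrolidin-1-yl, yet the change to compound 3 stays within the scatter, at a 1.3-fold lower number from compound 1 to compound 3 (0.12 log units; within the scatter). Among these compounds, only the chain ending in 4-methylpiperazin-1-yl stands clearly apart from the others, and nothing available explains this difference.

As far as these compounds go, the step between compound 2 and compound 3 alters both the end group and the chain that carries it, so the share of each remains unknown; a 4-(4-methylpiperazin-1-yl)butyl chain or a 3-(dimethylamino)propyl chain would separate the two. From the compounds shown here alone, it also remains open whether the second ring nitrogen of the piperazine matters, a question that a morpholine ring at the end of the same chain could address.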